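Swapping the carboxamide for a hydroxyl on the cyclohexyl ring

The source may report more compounds than this note shows. Statements on the series, on what has been measured and on what is new or still open speak of the compounds shown alone.

Compound 3 `N#Cc1cnc(NCc2cnccc2C(F)(F)F)cc1N[C@H]1CC[C@@H](C(N)=O)CC1` gives 7 nM in an assay on isolated protein for inhibition of protein kinase C theta type (Homo sapiens), read by TR-FRET, with a stated time of 2 h (a lower number here means a stronger inhibitor, a higher number a weaker inhibitor), the lowest of the three numbers measured. Compound 1 `N#Cc1cnc(NCc2cnccc2C(F)(F)F)cc1NC[C@H]1C[C@H](O)C1` gives 700 nM and compound 2 `N#Cc1cnc(NCc2cnccc2C(F)(F)F)cc1NC1CCOCC1` gives 900 nM; the two steps to compound 3 were large, a 100-fold lower number from compound 1 to compound 3 (2.00 log units; beyond the scatter) and a 130-fold lower number from compound 2 to compound 3 (2.11 log units; beyond the scatter). Compound 4 `CC1(C)C[C@@H](Nc2cc(NCc3cnccc3C(F)(F)F)ncc2C#N)CC[C@H]1O` differs from compound 3 in one place: 4-hydroxy-3,3-dimethylcyclohexyl in place of 4-carbamoylcyclohexyl on a nitrogen on an aromatic ring. Both measured steps show that the 4-carbamoylcyclohexyl group goes with a far lower number than other groups on that nitrogen, so removing it is expected to cost potency, though compound 4 keeps a six-membered carbon ring on the nitrogen and the same count of donors and acceptors. The expected step is an 8.6-fold higher number from compound 3 to compound 4 (0.93 log units; beyond the scatter). Compound 4 is therefore estimated at 60 nM, in a range from 15 nM to 300 nM.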

Compound 4, half-maximal inhibitory concentration: 120 nM
For compound 4 the middle estimate is 2.0-fold (0.30 log units) below the measured one; the range from low to high includes it.
By their numbers in this assay, from the lowest: compound 3; then compound 4; then compounds 1 and 2 (each within the scatter of the next).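

In this assay the 4-carbamoylcyclohexyl group proves hard to replace on this nitrogen: 4-hydroxy-3,3-dimethylcyclohexyl, which also has one six-membered carbon ring and the same number of heavy atoms, still loses ground (a 17-fold higher number from compound 3 to compound 4 (1.23 log units; beyond the scatter)). Yet it beats both other groups (a 7.5-fold lower number from compound 2 to compound 4 (0.88 log units; beyond the scatter); a 5.8-fold lower number from compound 1 to compound 4 (0.77 log units; beyond the scatter)), so some potency remains without the carbamoyl group. No evidence shown explains these differences. Going by these compounds, it remains open whether the hydroxyl or the two methyl groups matter more, and how a 4-aminocyclohexyl or 4-carboxycyclohexyl group would compare.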